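Swapping the Aryl Group on the Amine of Compound 3

The compounds below may be only part of what the source reports. "The series", "measured", "known", "first", "only" and "open" are said of these compounds alone.

Among the measured compounds shown here, compound 3 `Fc1cccc(-c2nc(Nc3ccc(Cl)cc3)c3cc(F)ccc3n2)c1` is the one compound here with a measured number: in a functional assay on U2OS cells (Homo sapiens) for cytotoxicity, read by MTT assay, with a stated time of 48 h (a lower number here means a stronger inhibitor, a higher number a weaker inhibitor), compound 3 gives 38400 nM. Compound 1 `COc1ccccc1Nc1nc(-c2cccc(F)c2)nc2ccc(F)cc12` reaches only a limit of the assay, giving > 50000 nM in this assay. Compound 2 `Fc1cccc(-c2nc(Nc3ccccc3F)c3cc(F)ccc3n2)c1` likewise gives only the limit > 50000 nM in this assay. Two of the three values thus sit at the limit of > 50000 nM in this assay, at which 2 of the 3 values shown sit. The steps of an at least 1.3-fold lower number from compound 1 to compound 3 (0.11 log units; that floor lies within the scatter) and an at least 1.3-fold lower number from compound 2 to compound 3 (0.11 log units; that floor lies within the scatter) each have a floor that lies within the scatter, and a step that the two limits leave unreadable from compound 1 to compound 2 cannot be read at all. Compound 4 `Fc1cccc(-c2nc(Nc3ccccc3Br)c3cc(F)ccc3n2)c1` carries 2-bromophenyl in place of 4-chlorophenyl on a nitrogen on an aromatic ring. For the measured compounds named here, the closest precedent is compound 2, whose 2-fluorophenyl group gave a limit, and whose measured step toward compound 3 stayed within the scatter; moving back to another substituted phenyl offers no ground to expect a step beyond the scatter in either direction. Compound 4 is therefore expected to show a 1.3-fold higher number from compound 3 to compound 4 (0.11 log units; within the scatter). The estimate for compound 4 is 50000 nM, between 20000 nM and 150000 nM.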

Compound 4, half-maximal inhibitory concentration: > 50000 nM
Compound 4: no number, only a limit; the forecaster's own chance of this, stated with the estimate: 55%; the middle value lies on the limit itself.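

The change to 2-bromophenyl gives an at least 1.3-fold higher number from compound 3 to compound 4 (0.11 log units; that floor lies within the scatter) in this assay, and that floor alone does not show that the swap matters. The 2-bromophenyl group now stands with the 2-methoxyphenyl and 2-fluorophenyl groups at the limit, while among the compounds shown only the 4-chlorophenyl group of compound 3 gives a number. The steps among compound 1, compound 2 and compound 4 cannot be read, and the series now crowds at a single limit: the limit of > 50000 nM in this assay, at which 3 of the 4 values shown sit.

Compound 3 and compound 4 differ in both the halogen and its place on the phenyl ring, and the compounds shown do not separate the two. Also open, going by these compounds, is whether a phenyl ring carrying an amine or a carboxylic acid would give a readable number.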